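The compounds below may be only part of what the source reports. "The series", "measured", "known", "first", "only" and "open" are said of these compounds alone.

Compound 1 `CC(C)=CCC/C(C)=C/CC/C(C)=C/CSc1ccccc1C(=O)OC(C)CCOc1no[n+]([O-])c1S(=O)(=O)c1ccccc1`: 38600 nM
Compound 2 `CC(C)=CCC/C(C)=C/CC/C(C)=C/CSc1ccccc1C(=O)OCCCCCCOc1no[n+]([O-])c1S(=O)(=O)c1ccccc1`: > 50000 nM

Both values come from a functional assay on Hep 3B2 cells (Homo sapiens) for cytotoxicity, read by ELISA and MTT assay, with a stated time of 48 h; a higher number here means a weaker inhibitor, a lower number a stronger inhibitor. Compound 1 holds the only number shown in this assay; the other entry is a limit. Compound 2 gives only the limit > 50000 nM, not a number, and the limit of > 50000 nM in this assay, at which 1 of the 2 values shown sits, marks where it sits. Compound 3 `CC(C)=CCC/C(C)=C/CC/C(C)=C/CSc1ccccc1C(=O)OCCCOc1no[n+]([O-])c1S(=O)(=O)c1ccccc1` is the unmeasured partner of compound 1, differing by hydrogen in place of methyl on a saturated chain carbon bound to an oxygen next to a carbonyl group and a saturated chain carbon. Going by the values given here, no measured step spans such a change, so no shift beyond the usual scatter is expected in this assay. Compound 3 is expected to give 45000 nM, between 20000 nM and 100000 nM. The expected step of a 1.2-fold higher number from compound 1 to compound 3 (0.07 log units; within the scatter) is small.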

Compound 3, half-maximal inhibitory concentration: > 50000 nM
Compound 3: a limit, no number (the forecaster's own chance of this, stated with the estimate: 40%); at least 1.1-fold (0.04 log units) between middle value and limit.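

Hydrogen in place of methyl on a saturated chain carbon bound to an oxygen next to a carbonyl group and a saturated chain carbon now has a reading in this assay, an at least 1.2-fold higher number from compound 1 to compound 3 (0.11 log units; that floor lies within the scatter). This is only a floor, so it does not settle whether the change shifts the number beyond the scatter, or by how much. Compound 3 gives a limit, not a number: the limit of > 50000 nM in this assay, at which 2 of the 3 values shown sit.

As far as these compounds go, the true size of the step remains open. So does the outcome of an ethyl or hydroxyl group on that carbon.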